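The source may report more compounds than this note shows. Statements on the series, on what has been measured and on what is new or still open speak of the compounds shown alone.

Measured compounds:

Compound 1, `CC(C)c1ccc(OC(Cc2ccc(C(F)(F)F)cc2)C(=O)O)cc1`: in a functional assay on the whole organism for inhibition, with Rattus norvegicus as the target (a lower number here means that less compound is needed, a higher number that more compound is needed for the effect), compound 1 gives 10 mg/kg.
Compound 2, `COc1ccccc1CC(Oc1ccc(C(C)C)cc1)C(=O)O`: compound 2 gives > 10 mg/kg in this assay, which is a limit and not a number.
Compound 3, `COc1ccc(CC(Oc2ccc(C(C)C)cc2)C(=O)O)cc1`: compound 3 gives > 50 mg/kg in this assay, likewise a limit.

Only compound 1 has a number. Compound 2 stands at a limit, (the limit of > 10 mg/kg in this assay, at which 1 of the 3 values shown sits), and compound 3 at a second limit, (the limit of > 50 mg/kg in this assay, at which 1 of the 3 values shown sits). Among the measured compounds shown here, the one step that can be sized runs an at least 5.0-fold higher number from compound 1 to compound 3 (0.69 log units; beyond the scatter); it concerns the substituent on the aromatic ring of the benzyl part and leaves the central chain untouched.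

Compound 4, `COc1ccccc1CC(C)(Oc1ccc(C(C)C)cc1)C(=O)O`, has not yet been measured. It differs from compound 2 in one place: methyl in place of hydrogen on a saturated chain carbon bound to a carbonyl carbon, an oxygen on an aromatic ring and a saturated chain carbon. No measured pair in the series changes that chain carbon, so no step bears directly on this change, and the size of the methyl effect in this assay cannot be read from the numbers shown. With compound 2 itself at a limit, the step from compound 2 to compound 4 is expected to be small or not resolvable, a step that the limit leaves unreadable from compound 2 to compound 4. Compound 4 is therefore expected to give about 20 mg/kg, within 7 mg/kg to 60 mg/kg, with a fair chance that only a limit is reported again.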

Compound 4, dose for half-maximal effect: > 10 mg/kg
Compound 4: only a limit was reported; the forecaster's own chance of this, stated with the estimate: 60%; the middle value lies beyond the limit too.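

Compound 2 and compound 4 share one limit and neither has a number, so no step can be read between them: the limit of > 10 mg/kg in this assay, at which 2 of the 4 values shown sit.

Still open, going by these compounds, is whether methyl in place of hydrogen on that saturated chain carbon changes the dose needed in this assay at all, and in which direction.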